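A few compounds are considered here, and "the series" means these few. Any claim that something is new, unique, unknown or untested is made for them only; others in the source may bear on it.

Measured in a functional assay on HepG2 cells (Homo sapiens) for cytotoxicity, read by MTT assay, with a stated time of 72 h; on this read-out higher numbers stand for weaker inhibition and lower numbers for stronger inhibition:
- compound 2 `O=S(=O)(Nc1cc(-c2ccc3nccc(-c4ccc(Cn5cncn5)cc4)c3c2)cnc1Cl)c1ccc(F)cc1F`: 2040 nM
- compound 3 `O=S(=O)(Nc1cc(-c2ccc3nccc(-c4ccc(Cn5cncn5)cc4)c3c2)cnc1Cl)c1ccc(F)cc1`: 9600 nM
- compound 1 `COc1ncc(-c2ccc3nccc(-c4ccc(Cn5cncn5)cc4)c3c2)cc1NS(=O)(=O)c1ccc(F)cc1F`: "not determined" (no result reported)

Compound 3 gives the highest of the two numbers in this assay; its nearest neighbour is compound 2, and the move a 4.7-fold higher number from compound 2 to compound 3 (0.67 log units; beyond the scatter) lies beyond the scatter. Compound 4 `COc1ncc(-c2ccc3nccc(-c4ccc(Cn5cncn5)cc4)c3c2)cc1NS(=O)(=O)c1ccc(F)cc1` differs from compound 3 by methoxy in place of chloro on an aromatic carbon. No measured step covers this exchange: the only step shown, from compound 2 to compound 3, concerns a different group, and compound 1, which would carry the same methoxy on the same ring, has no number. With nothing to anchor a direction, the expectation is no step beyond the scatter, a 1.1-fold lower number from compound 3 to compound 4 (0.03 log units; within the scatter), with a wide range. Compound 4 is therefore estimated at 9000 nM (range 2500 nM to 32000 nM).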

Compound 4, half-maximal inhibitory concentration: 12700 nM
For compound 4 the middle estimate is 1.4-fold (0.15 log units) below the measured one; the measured number falls inside the stated range.
By their numbers in this assay, from the lowest: compound 2; then compounds 3 and 4 (each within the scatter of the next).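

In this assay, methoxy in place of chloro on the aromatic carbon next to the ring nitrogen gives a 1.3-fold higher number from compound 3 to compound 4 (0.12 log units; within the scatter). Among these compounds, this is the first reading at this position, and with the ((4-fluorophenyl)sulfonyl)amino group held constant, the exchange stays within the scatter. Nothing at hand offers an explanation for this result.

The same exchange cannot be read in the difluoro pair: compound 1 gives "not determined" (no result reported). Also open, on these data alone, is how an amine or a longer ethoxy chain would read at this position.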